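A few compounds are considered here, and "the series" means these few. Any claim that something is new, unique, unknown or untested is made for them only; others in the source may bear on it.

Measured so far in a functional assay on HeLa cells (Homo sapiens) for cytotoxicity, read by MTT assay, with a stated time of 48 h; a lower number here means a stronger inhibitor, a higher number a weaker inhibitor:
compound 1 `COc1ccccc1C(C1=C(O)C(=O)c2ccccc2C1=O)c1c[nH]c2ccccc12` gives 128000 nM
compound 2 `O=C1C(O)=C(C(c2ccc(F)cc2)c2c[nH]c3ccccc23)C(=O)c2ccccc21` gives 15800 nM

Compound 2 holds the lower of the two numbers in this assay, and the gap to compound 1 is the step of an 8.1-fold lower number from compound 1 to compound 2 (0.91 log units; beyond the scatter), beyond the scatter. Compound 3 `COc1ccc(C(C2=C(O)C(=O)c3ccccc3C2=O)c2c[nH]c3ccccc23)cc1Br` has no number yet; it differs from compound 2 by 3-bromo-4-methoxyphenyl in place of 4-fluorophenyl on a saturated chain carbon bound to an aromatic carbon and a double-bonded ring carbon. Among the compounds with values here, the one measured step, an 8.1-fold lower number from compound 1 to compound 2 (0.91 log units; beyond the scatter), concerns an exchange of the aryl group at this same place and shows that such an exchange can move the number well beyond the scatter; it does not, however, test 3-bromo-4-methoxyphenyl, and the 2-methoxyphenyl of compound 1 is a different group. Within the data shown here, with no direct precedent, a number for compound 3 somewhere between the two measured ones is expected, a weakening step a 1.9-fold higher number from compound 2 to compound 3 (0.28 log units; within the scatter) in this assay. The estimate for compound 3 is 30000 nM, with a range from 8000 nM to 110000 nM.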

Compound 3, half-maximal inhibitory concentration: 7320 nM
The estimate for compound 3 lay 4.1-fold (0.61 log units) above the measured number; measured number below the stated range.
By their numbers in this assay, from the lowest: compound 3; then compound 2; then compound 1.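

In this assay, 3-bromo-4-methoxyphenyl on the saturated chain carbon gives a 2.2-fold lower number from compound 2 to compound 3 (0.33 log units; beyond the scatter), so this place accepts a bulkier, two-substituent aryl group without any rise in the number. Compound 1 and compound 3 both carry a methoxy on the aryl group, yet the exchange gives a 17-fold lower number from compound 1 to compound 3 (1.24 log units; beyond the scatter), so the presence of a methoxy does not by itself fix the number at this place. No measurement at hand explains either step.

The compounds shown do not separate the contribution of the bromine from that of the methoxy within 3-bromo-4-methoxyphenyl. On these data alone, how an aryl group bearing an amine or a carboxylic acid would read at this place in this assay also remains open.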